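Swapping the aryl group on the piperidine nitrogen

The compounds below may be only part of what the source reports. "The series", "measured", "known", "first", "only" and "open" are said of these compounds alone.

Measured compounds:
compound 1, `O=C1COc2ccc(NC(=O)C3CCN(c4ccccc4Br)CC3)cc2N1` — 160 nM
compound 2, `Cc1cccc(N2CCC(C(=O)Nc3ccc4c(c3)NC(=O)CO4)CC2)c1C` — 60 nM

In a functional assay for antagonist activity at transient receptor potential cation channel subfamily V member 1 (Homo sapiens), read by FLIPR and calcium flux (a higher number here means a weaker inhibitor, a lower number a stronger inhibitor), compound 2 gives 60 nM, the lowest of the two numbers; its nearest neighbour is compound 1, and a 2.7-fold lower number from compound 1 to compound 2 (0.43 log units; beyond the scatter), a modest step beyond the scatter. Compound 3, `O=C1COc2ccc(NC(=O)C3CCN(c4ccccc4Cl)CC3)cc2N1`, has not yet been measured in this assay. It differs from compound 2 in one place: 2-chlorophenyl in place of 2,3-dimethylphenyl on an amine nitrogen in a ring. Within the data shown here, the only measured step that bears on this change is the one in which 2-bromophenyl gave way to 2,3-dimethylphenyl, from compound 1 to compound 2. The 2-chlorophenyl of compound 3 stands closer to the 2-bromophenyl of compound 1 than to the 2,3-dimethylphenyl of compound 2, so a number near that of compound 1 is expected, meaning a modest rise from compound 2. The expected step is a 2.2-fold higher number from compound 2 to compound 3 (0.34 log units; beyond the scatter). Compound 3 is therefore estimated at 130 nM, with a range from 50 nM to 350 nM.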

Compound 3, half-maximal inhibitory concentration: 220 nM
Beside the measured number, compound 3's estimate is 1.7-fold (0.23 log units) below it, within the range that was stated.
By their numbers in this assay, from the lowest: compound 2; then compounds 1 and 3 (each within the scatter of the next).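

In this assay, exchanging bromo for chloro on the aromatic carbon makes no readable difference, with a 1.4-fold higher number from compound 1 to compound 3 (0.14 log units; within the scatter), so the two halogen-bearing phenyl groups on the ring nitrogen stand together. Moving from 2,3-dimethylphenyl to 2-chlorophenyl gives a 3.7-fold higher number from compound 2 to compound 3 (0.56 log units; beyond the scatter), so the lower number of compound 2 now holds against a second halogen and not only against the bromo group of compound 1. Nothing measured here explains this gap.

The compounds shown do not separate the two methyl groups of 2,3-dimethylphenyl, so it remains open how a 2-methylphenyl or a 3-methylphenyl group on the same nitrogen would compare. Going by these compounds, it also remains open whether a 2-fluorophenyl or a 2-methoxyphenyl group would fall with compound 1 and compound 3 or with compound 2.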